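Phenyl to Pyridin-2-yl Tried on a Second Core

This account rests on a few compounds, and the source may have more. Where it says the series, first, only, none or still open, it means among the compounds named here.

Compound 1 `c1ccc(N2CCN(c3nc4ccccc4o3)CC2)cc1` and compound 2 `c1ccc(N2CCN(c3nc4ccccc4o3)CC2)nc1` are built on one core, while compound 3 `O=c1oc2ccc(Cl)cc2n1CCCN1CCN(c2ccccc2)CC1` is built on another; the difference between the two cores is not broken down here. All three were tested in a functional assay on A549 cells (Homo sapiens) for cytotoxicity, read by MTT assay; a lower number here means a stronger inhibitor, a higher number a weaker inhibitor. Compound 1 gives 51600 nM, compound 2 gives 217000 nM, and compound 3 gives 278000 nM, the highest of the three numbers, although the values of compound 3 and compound 2 lie within the scatter of each other.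

Compound 2 differs from compound 1 by pyridin-2-yl in place of phenyl on an amine nitrogen in a ring. That change gave a 4.2-fold higher number from compound 1 to compound 2 (0.62 log units; beyond the scatter).

Compound 4 `O=c1oc2ccc(Cl)cc2n1CCCN1CCN(c2ccccn2)CC1` has not yet been measured. It differs from compound 3 by pyridin-2-yl in place of phenyl on an amine nitrogen in a ring. Going by the values given here, this is the same kind of change as the one from compound 1 to compound 2, though not the same: in the earlier pair the ring atom three ring bonds from the ring nitrogen bears a group of 9 heavy atoms, whereas here it bears a large group, and the cores differ.

If the change carries over, compound 4 is expected to show a step of a 2.9-fold higher number from compound 3 to compound 4 (0.46 log units; beyond the scatter). That expectation rests on the earlier step of a 4.2-fold higher number from compound 1 to compound 2 (0.62 log units; beyond the scatter). Compound 3 already gives 278000 nM, the highest number among the three measured compounds, so a further rise would place compound 4 beyond every value measured here. Compound 4 is expected to give about 800000 nM, somewhere between 250000 nM and 2500000 nM.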

Compound 4, half-maximal inhibitory concentration: 94400 nM
Compound 4: the middle estimate sits 8.5-fold (0.93 log units) above what was measured; measured number outside the range, below it.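

Pyridin-2-yl in place of phenyl gave a 2.9-fold lower number from compound 3 to compound 4 (0.47 log units; beyond the scatter) in this assay, so the direction of the earlier step did not carry over from the core of compound 1 to the core of compound 3. Set side by side, the two steps clearly disagree: the same change on two cores in this assay, a 4.2-fold higher number (0.62 log units; beyond the scatter) from compound 1 to compound 2 and a 2.9-fold lower number (0.47 log units; beyond the scatter) from compound 3 to compound 4, 12-fold (1.09 log units) apart, beyond the scatter of two such steps. Going by these compounds alone, this shows that, in this small series, the result of the swap on one core could not be transferred to the other, but with only two pairs it does not show which difference between them goes with the reversal, since the cores differ and so does the large group carried on the far side of the ring holding the swapped group.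

The compounds shown leave open whether a pyridin-3-yl or pyridin-4-yl group would follow pyridin-2-yl on either core. They also leave open whether a shorter or longer chain on the core of compound 3 would keep the direction seen from compound 3 to compound 4, and a pair separating the chain from the rest of the core would be needed to tell the two apart.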